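The source may report more compounds than this note shows. Statements on the series, on what has been measured and on what is new or still open speak of the compounds shown alone.

Measured compounds in an ADME assay on isolated protein for inhibition of Amine oxidase [flavin-containing] B (Homo sapiens); a lower number here means a stronger inhibitor, a higher number a weaker inhibitor:

compound 1 `C#CCNC1CCc2c(SCCc3ccc(Br)cc3)cccc21`: 1250 nM
compound 2 `C#CCNC1CCc2c(OCc3cccc(C(F)(F)F)c3)cccc21`: 5410 nM
compound 3 `C#CCNC1CCc2c(SCc3cccc(F)c3)cccc21`: 11600 nM

Among the three, compound 1 has the lowest number in this assay; compound 2 gives a higher number, and compound 3 a number higher still, both gaps beyond the scatter. For the measured compounds named here, no pair among the three differs in one place only, so no single-point step is known.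

Compound 4 `C#CCNC1CCc2c(SCCc3ccc(C)cc3)cccc21` differs from compound 1 in one place: methyl in place of bromo on an aromatic carbon, on an aromatic carbon of a six-membered aromatic ring of carbon only, para to a large group. Cut one bond further out, the change reads 4-bromophenyl to 4-methylphenyl. Going by the values given here, no measured pair shows what such a swap does here, so the expectation rests on compound 1 alone. The step from compound 1 to compound 4 in this assay is expected to be small, at most slightly toward a higher number, and possibly none beyond the scatter: a 1.4-fold higher number from compound 1 to compound 4 (0.16 log units; within the scatter). Compound 4 is therefore estimated at 1800 nM in this assay, with a range from 600 nM to 5500 nM.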

Compound 4, half-maximal inhibitory concentration: 4520 nM
The estimate for compound 4 lay 2.5-fold (0.40 log units) below the measured number; the range from low to high includes it.
By their numbers in this assay, from the lowest: compound 1; then compounds 4 and 2 (each within the scatter of the next); then compound 3.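

In this assay, for the compounds shown here, methyl in place of bromo on an aromatic carbon gives a 3.6-fold higher number from compound 1 to compound 4 (0.56 log units; beyond the scatter) and is the first single-point step. The group para to a large group on this six-membered aromatic ring therefore matters in this read-out, even though the swap exchanges one heavy atom for one heavy atom and leaves the counted donors, acceptors and charge unchanged. Nothing available accounts for the size or direction of this step.

Still open, on these data alone, is whether bromo stands out at this place or whether chloro, methoxy or plain hydrogen would give a similar number. Also open, as far as these compounds go, is whether the same swap gives a similar step on the chain of compound 3 or the oxygen-linked chain of compound 2.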